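Sulfonyl aryl variation in the triazole-linked butenolide series

This account rests on a few compounds, and the source may have more. Where it says the series, first, only, none or still open, it means among the compounds named here.

Compound 1 `O=C1O[C@H]([C@@H](O)Cn2cc(CNS(=O)(=O)c3ccc(F)cc3)nn2)C(OCc2ccccc2)=C1OCc1ccccc1` is examined in a functional assay on HeLa cells (Homo sapiens) for antiproliferative activity, read by MTT assay, with a stated time of 72 h (on this read-out lower numbers stand for stronger inhibition and higher numbers for weaker inhibition), where compound 1 gives 25000 nM. Within the data shown here, its only neighbour is compound 2 `C[Si](C)(C)c1cn(C[C@H](O)[C@H]2OC(=O)C(OCc3ccccc3)=C2OCc2ccccc2)nn1`, which in this assay gives 22300 nM; the change a 1.1-fold lower number from compound 1 to compound 2 (0.05 log units; within the scatter) does not set the two compounds apart, so compound 1 stands level with compound 2 rather than ahead of or behind it.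

Compound 3 `O=C1O[C@H]([C@@H](O)Cn2cc(CNS(=O)(=O)c3ccc(Cl)cc3F)nn2)C(OCc2ccccc2)=C1OCc1ccccc1` is not yet measured. It differs from compound 1 by 4-chloro-2-fluorophenyl in place of 4-fluorophenyl on a sulfonyl sulfur. Among the measured compounds shown here, no measured step touches the aryl group on the sulfonyl sulfur: the single step available, from compound 1 to compound 2, exchanges the whole sulfonamide arm for a trimethylsilyl group and stays within the scatter. That step bears on compound 3 only in showing that this end of the molecule has so far made little difference in this assay. On that basis no step beyond the scatter is expected in either direction.

Compound 3 is therefore expected to give 24000 nM in this assay, within 10000 nM to 60000 nM, which corresponds to an expected change of a 1.0-fold lower number from compound 1 to compound 3 (0.02 log units; within the scatter).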

Compound 3, half-maximal inhibitory concentration: 20700 nM
Estimate against measurement, compound 3: 1.2-fold (0.06 log units) above; measured number inside the range.
By their numbers in this assay, from the lowest: compounds 3, 2 and 1 (each within the scatter of the next).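

In this assay, the step that touches the aryl group on the sulfonyl sulfur, a 1.2-fold lower number from compound 1 to compound 3 (0.08 log units; within the scatter), lies within the scatter, so 4-chloro-2-fluorophenyl in place of 4-fluorophenyl does not set the two compounds apart. The step from compound 1 to compound 2 exchanged the whole sulfonamide arm, whereas this one keeps the arm and alters only the aryl group, giving a direct reading at this position: for this pair of aryl groups, the added chlorine and the second fluorine leave the read-out unresolved from that of compound 1. No measurement at hand offers an explanation for this result.

On these data alone, what an amine or a carboxylic acid on the aryl ring, or a longer chain in place of the aryl group on the sulfonyl sulfur, would do in this assay remains open. Also open, as far as these compounds go, is whether any change to the core of compound 1, rather than to this arm, would move the number beyond the scatter.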